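Swapping the aryl group on the piperazine: compound 3

The compounds below may be only part of what the source reports. "The series", "measured", "known", "first", "only" and "open" are said of these compounds alone.

Compound 1 `CC(C)N1CCN(Cc2csc(N)c2C(=O)c2ccc(Cl)cc2)CC1`: -1%
Compound 2 `Nc1scc(CN2CCN(c3cc(F)ccc3F)CC2)c1C(=O)c1ccc(Cl)cc1`: 3.1%

In a functional assay on CHO cells with adenosine receptor A1 (Homo sapiens) as the target, read by cAMP accumulation and immunoassay, with a stated time of 6 min, tested at 0.01 uM (on this read-out higher numbers stand for a weaker effect at the one concentration tested and lower numbers for a stronger effect), compound 1 gives -1% and compound 2 gives 3.1%; the two numbers lie together, with the step of a number 4.1 percentage points higher from compound 1 to compound 2 (within the scatter). Compound 3 `Nc1scc(CN2CCN(c3cccc(Cl)c3)CC2)c1C(=O)c1ccc(Cl)cc1` carries 3-chlorophenyl in place of 2,5-difluorophenyl on an amine nitrogen in a ring. Going by the values given here, the only step measured so far, from isopropyl to an aromatic ring on the same ring nitrogen, stayed within the scatter, so a second aromatic ring at that place is expected to leave the number where it stands, a step of a number 1.1 percentage points lower from compound 2 to compound 3 (within the scatter). Compound 3 is therefore estimated at 2%, with a range from -8% to 12%.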

Compound 3, a percentage reported as activity, at one concentration (the size of the read-out at that concentration, not a potency): -3.1%
Compound 3: middle estimate off by 5.1 percentage points, on the high side; the range from low to high includes it.
By their numbers in this assay, from the lowest: compounds 3, 1 and 2 (each within the scatter of the next).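

In this assay the new group brings a number 6.2 percentage points lower from compound 2 to compound 3 (within the scatter) and a number 2.1 percentage points lower from compound 1 to compound 3 (within the scatter). On this amine nitrogen in a ring, isopropyl, 2,5-difluorophenyl and 3-chlorophenyl therefore cannot be ranked against one another at the one concentration tested. Nothing available explains why these numbers lie together.

On these data alone, whether a different kind of group on that nitrogen, such as a carboxylic acid or a longer alkyl chain, would move the number stays open. As far as these compounds go, whether these three compounds would separate at other concentrations also stays open.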